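Working notes: hydrogen in place of cyano, compound 4

A few compounds are considered here, and "the series" means these few. Any claim that something is new, unique, unknown or untested is made for them only; others in the source may bear on it.

- compound 1 `CC[C@H]1CC[C@H](c2ccc(NC(=S)Nc3cccc(C(F)(F)F)c3)cc2)CC1`: 10000 nM
- compound 2 `FC(F)(F)c1cccc(NC(=S)Nc2ccc(Cl)cc2)c1`: 10000 nM
- compound 3 `N#Cc1ccc(NC(=S)Nc2cccc(C(F)(F)F)c2)cc1`: 9500 nM

All three values come from an ADME assay on BHK cells (Mesocricetus auratus) for cytotoxicity, read by MTT assay, with a stated time of 96 h; on this read-out higher numbers stand for lower toxicity in this test and lower numbers for higher toxicity in this test. Compound 3 stands within the scatter of both other compounds, with a 1.1-fold lower number from compound 1 to compound 3 (0.02 log units; within the scatter) and a 1.1-fold lower number from compound 2 to compound 3 (0.02 log units; within the scatter).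

The next compound to consider is compound 4 `FC(F)(F)c1cccc(NC(=S)Nc2ccccc2)c1`. It carries hydrogen in place of cyano on an aromatic carbon, para to a large group: hydrogen in place of cyano on an aromatic carbon.

The three measured steps all fall at this same aromatic carbon. They exchange 4-ethylcyclohexyl, chloro and cyano among themselves. Besides the two steps above, there is no change at the digits printed from compound 1 to compound 2 (within the scatter). None of the three goes beyond the scatter in this assay, although the groups exchanged differ widely in size. Among the measured compounds shown here, no measured compound has hydrogen at this carbon, so the expectation rests on an extension from three compounds only.

On that basis, no change beyond the scatter is expected in this assay. The expected step is no change at the digits printed from compound 3 to compound 4 (within the scatter). Compound 4 is estimated at 9500 nM, with an expected range of 4500 nM to 20000 nM.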

Compound 4, half-maximal cytotoxic concentration: 41000 nM
Compound 4: the middle estimate sits 4.3-fold (0.64 log units) below what was measured, outside the stated range (above it).
By their numbers in this assay, from the lowest: compounds 3, 1 and 2 (each within the scatter of the next); then compound 4.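

In this assay, among the compounds shown here, compounds 1, 2 and 3 stand within the scatter of one another, and the change to hydrogen is the first at this aromatic carbon to go beyond it, with a 4.3-fold higher number from compound 3 to compound 4 (0.64 log units; beyond the scatter) together with a 4.1-fold higher number from compound 2 to compound 4 (0.61 log units; beyond the scatter) and a 4.1-fold higher number from compound 1 to compound 4 (0.61 log units; beyond the scatter) as steps of closely similar size. Among these four compounds the division at this position therefore lies between hydrogen and the three larger groups, not among 4-ethylcyclohexyl, chloro and cyano, so that compound 4 alone stands apart, with the highest number and the lowest toxicity in this test. Nothing shown gives a reason for this separation, and no supporting measurement bears on it.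

The compounds shown leave open whether a fluorine atom, a methyl group, an amine or a carboxylic acid at this aromatic carbon would group with hydrogen or with the other three substituents. They also leave open whether the same separation would hold if the trifluoromethyl group of the shared core were replaced by a methoxy group or a bromine atom.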